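The source may report more compounds than this note shows. Statements on the series, on what has been measured and on what is new or still open speak of the compounds shown alone.

Measured so far in a functional assay on K562 cells (Homo sapiens), read by MTT assay, with a stated time of 72 h; a lower number here means a stronger inhibitor, a higher number a weaker inhibitor:
compound 1 `CNc1ncnc2c1c(-c1ccco1)cn2[C@@H]1O[C@H](CO)[C@@H](O)[C@H]1O`: 220 nM
compound 2 `O=c1[nH]cnc2c1c(-c1ccccc1)cn2[C@@H]1O[C@H](CO)[C@@H](O)[C@H]1O`: > 20000 nM, a limit
compound 3 `O=c1[nH]cnc2c1c(-c1cc3ccccc3o1)cn2[C@@H]1O[C@H](CO)[C@@H](O)[C@H]1O`: > 20000 nM, a limit

Compound 2 stands at a limit and has no number. Compound 3 also gives a limit, and the limit of > 20000 nM in this assay, at which 2 of the 3 values shown sit, marks where both sit. Compound 4 `Nc1nc2c(c(-c3ccccc3)cn2[C@@H]2O[C@H](CO)[C@@H](O)[C@H]2O)c(=O)[nH]1` differs from compound 2 by one change: amino in place of hydrogen on an aromatic carbon, between two ring nitrogen atoms. Within the data shown here, the only measured step, a step that the two limits leave unreadable from compound 2 to compound 3, concerns another group and gives no size. Compound 2 differs from compound 1 in more than one place, so the value of compound 1 at 220 nM sizes nothing here. No clear shift is therefore expected in this assay, and the direction is open. The expected change is a step that the limit leaves unreadable from compound 2 to compound 4. The estimate for compound 4 is 25000 nM, with an expected range of 8000 nM to 60000 nM.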

Compound 4, half-maximal inhibitory concentration: > 20000 nM
Compound 4 ended at the assay's limit (the forecaster's own chance of this, stated with the estimate: 75%); the middle value is on the limit's open side.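

Compound 2 and compound 4 both stand at a limit, not a number, so the step from compound 2 to compound 4 cannot be read: the limit of > 20000 nM in this assay, at which 3 of the 4 values shown sit. Going by these compounds, whether amino in place of hydrogen shifts activity at all stays open.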